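Carbonyl substituent swap on the benzyloxy coumarin series

This account rests on a few compounds, and the source may have more. Where it says the series, first, only, none or still open, it means among the compounds named here.

Compound 1 `CC(=O)COc1cc(=O)oc2cc(OCc3cccc(Cl)c3)ccc12` gives 26.9 nM in an assay on isolated protein (strain Sprague-Dawley) for inhibition of Amine oxidase [flavin-containing] B (Rattus norvegicus), read by spectrophotometry, with a stated time of 5 min; on this read-out lower numbers stand for stronger inhibition and higher numbers for weaker inhibition. Compound 2 `O=C(COc1cc(=O)oc2cc(OCc3cccc(Cl)c3)ccc12)N1CCCCC1`, which carries piperidin-1-yl in place of methyl on the carbonyl carbon, gives 38900 nM; the step of a 1400-fold higher number from compound 1 to compound 2 (3.16 log units; beyond the scatter) is the only one available and it is large. Among the compounds with values here, compound 2 thus stands as the weaker of the two measured compounds, the highest number so far, with compound 1 far below it. Compound 3 `CCOC(=O)Nc1cc(=O)oc2cc(OCc3cccc(Cl)c3)ccc12` differs from compound 2 by (ethoxycarbonyl)amino in place of ((piperidin-1-yl)carbonyl)methoxy on an aromatic carbon. Within the data shown here, no measured step covers this exchange directly; the sole step bears on it only insofar as it shows that enlarging the group on that side costs heavily, and compound 3 instead carries a smaller group. A lower number than compound 2 is therefore expected for compound 3, with the step of a 130-fold lower number from compound 2 to compound 3 (2.11 log units; beyond the scatter) judged sizeable but uncertain in magnitude. Compound 3 is estimated at 300 nM, within 15 nM to 6000 nM.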

Compound 3, half-maximal inhibitory concentration: 589 nM
For compound 3 the middle estimate is 2.0-fold (0.29 log units) below the measured one; measured number inside the range.
By their numbers in this assay, from the lowest: compound 1; then compound 3; then compound 2.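

In this assay, the aromatic carbon opposite the ring oxygen accepts a group linked through nitrogen: (ethoxycarbonyl)amino recovers much of the loss seen with ((piperidin-1-yl)carbonyl)methoxy (a 66-fold lower number from compound 2 to compound 3 (1.82 log units; beyond the scatter)). It does not match the 2-oxopropoxy group of compound 1 (a 22-fold higher number from compound 1 to compound 3 (1.34 log units; beyond the scatter)), so the three groups now form an order at this one position, spanning a wide range of numbers. No measurement on hand accounts for these differences.

The three compounds do not separate the contribution of the nitrogen link from that of the ethoxycarbonyl part of the group. A simple amine or a carboxylic acid on this aromatic carbon, or a longer chain in place of the methyl of compound 1, would show how far this order extends.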